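Hexafluoroisopropoxy in place of sec-butoxy on the shared core

The compounds below may be only part of what the source reports. "The series", "measured", "known", "first", "only" and "open" are said of these compounds alone.

Compound 1 `CCOc1ccc(-c2nc(-c3ccc(CCC(=O)O)cc3C)no2)cc1C(F)(F)F` gives in a functional assay on CHO cells with sphingosine 1-phosphate receptor 2 (Homo sapiens) as the target, read by GTPgammaS binding (a higher number here means that more compound is needed for the effect, a lower number that less compound is needed), only an assay limit, > 10000 nM.
Compound 2 `CC[C@H](C)Oc1ccc(-c2nc(-c3ccc(CCC(=O)O)cc3C)no2)cc1C#N` gives in this assay only an assay limit, > 10000 nM.

Compound 2 thus stands at the limit of > 10000 nM in this assay, at which 2 of the 2 values shown sit, and no true number is known for it. Compound 3 `Cc1cc(CCC(=O)O)ccc1-c1noc(-c2ccc(OC(C(F)(F)F)C(F)(F)F)c(C#N)c2)n1` differs from compound 2 in one place: 2,2,2-trifluoro-1-(trifluoromethyl)ethyl in place of sec-butyl on an oxygen on an aromatic ring. Going by the values given here, no measured step between compounds exists to guide the change, so no move beyond the scatter is expected in this assay in either direction, and a further limit is the likeliest outcome. The step is expected to read a step that the limit leaves unreadable from compound 2 to compound 3. Compound 3 is estimated at 20000 nM, within 5000 nM to 100000 nM.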

Compound 3, half-maximal effective concentration: > 10000 nM
Compound 3: a limit, no number; the forecaster's own chance of this, stated with the estimate: 85%; the middle value is on the limit's open side.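

Going by these compounds alone, compound 3 gives only an assay limit, > 10000 nM, as compound 2 does, so no step between compound 2 and compound 3 can be read. The true values of compound 1, compound 2 and compound 3 in this assay stay open, and the only reading is a shared limit: the limit of > 10000 nM in this assay, at which 3 of the 3 values shown sit.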